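Chloro for Methoxy: Expecting Compound 4 in a Cell Assay

The compounds below may be only part of what the source reports. "The series", "measured", "known", "first", "only" and "open" are said of these compounds alone.

Measured so far:
compound 1, `COc1ccccc1N1CCN(CC(=O)N2CCN(c3nnc(-c4ccccc4)c(-c4ccccc4)n3)CC2)CC1`: 167000 nM in a functional assay on MCF7 cells (Homo sapiens) for cytotoxicity, read by MTT assay, with a stated time of 24 h; on this read-out lower numbers stand for stronger inhibition and higher numbers for weaker inhibition
compound 2, `O=C(CN1CCN(c2ccccc2Cl)CC1)N1CCN(c2nnc(-c3ccccc3)c(-c3ccccc3)n2)CC1`: 263000 nM
compound 3, `COc1ccccc1N1CCN(CC(=O)N2CCN(c3nnc(-c4ccc(C)cc4)c(-c4ccc(C)cc4)n3)CC2)CC1`: 59400 nM

Compound 4, `Cc1ccc(-c2nnc(N3CCN(C(=O)CN4CCN(c5ccccc5Cl)CC4)CC3)nc2-c2ccc(C)cc2)cc1`, has not yet been measured in this assay. It differs from compound 3 by chloro in place of methoxy on an aromatic carbon. The same change has already been made once, from compound 1 to compound 2: chloro in place of methoxy on an aromatic carbon, where it gave a 1.6-fold higher number from compound 1 to compound 2 (0.20 log units; within the scatter). The two place descriptions agree word for word, so this is the same change. The difference between the core of compound 1 and the core of compound 3 is not broken down here; compound 3 simply gives the lowest number of the three.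

Because the earlier step of a 1.6-fold higher number from compound 1 to compound 2 (0.20 log units; within the scatter) stayed within the scatter, compound 4 is expected to show a similar small step, a 1.6-fold higher number from compound 3 to compound 4 (0.20 log units; within the scatter). Compound 4 is therefore estimated at 95000 nM, with a likely range from 40000 nM to 220000 nM.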

Compound 4, half-maximal inhibitory concentration: 859000 nM
For compound 4 the middle estimate is 9.0-fold (0.96 log units) below the measured one, and the stated range ends below it.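

On the second core, chloro in place of methoxy gives a 14-fold higher number from compound 3 to compound 4 (1.16 log units; beyond the scatter) in this assay. The size of this step therefore does not carry over from one core to the other: the same change on two cores in this assay, a 1.6-fold higher number (0.20 log units; within the scatter) from compound 1 to compound 2 and a 14-fold higher number (1.16 log units; beyond the scatter) from compound 3 to compound 4, 9.2-fold (0.96 log units) apart, beyond the scatter of two such steps. Going by these compounds alone, this shows only that the same change can have a very different size on a different core; with just two pairs, it does not explain the gap or predict the size of the step on any further core.

The compounds shown leave open how other groups in the same place, such as fluoro, methyl or an amine, would behave on these two cores. They also leave open whether those groups would show a similar gap between the cores.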